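Methoxy to hydroxy on the styryl ring of compound 1

The compounds below may be only part of what the source reports. "The series", "measured", "known", "first", "only" and "open" are said of these compounds alone.

Compound 1 `CCN(CC)c1ccc(/C=C2\C(=O)N(C3CCCCC3)C(=S)N2C)c(OC)c1` gives 1340 nM in an assay on isolated protein for inhibition of NADPH oxidase 4 (Homo sapiens), read by chemiluminescence, in the presence of a further agent that is not named here; a lower number here means a stronger inhibitor, a higher number a weaker inhibitor. Compound 2 `CCN(CC)c1ccc(/C=C2\C(=O)N(c3ccccc3)C(=S)N2C)c(OC)c1`, which carries phenyl in place of cyclohexyl on the amide-type nitrogen in the ring, gives 1170 nM. The step of a 1.1-fold lower number from compound 1 to compound 2 (0.06 log units; within the scatter) is the only measured one in the series, and the two numbers lie within the scatter of each other, so compound 1 and compound 2 cannot be told apart on these data.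

Compound 3 `CCN(CC)c1ccc(/C=C2\C(=O)N(C3CCCCC3)C(=S)N2C)c(O)c1` differs from compound 1 at a different place: hydrogen in place of methyl on an oxygen on an aromatic ring. Among the compounds with values here, neither measured compound varies at this oxygen, so no measured step bears on this change; the one step available concerns the ring nitrogen substituent and is itself within the scatter. As far as these compounds go, without a guide from the series, the working expectation is no step beyond the scatter in this assay, in either direction, with a wide range to reflect that the position is untested. Compound 3 is therefore estimated at 1300 nM, within 450 nM to 3800 nM. The expected step from compound 1 is a 1.0-fold lower number from compound 1 to compound 3 (0.01 log units; within the scatter).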

Compound 3, half-maximal inhibitory concentration: 2350 nM
Estimate against measurement, compound 3: 1.8-fold (0.26 log units) below, within the range that was stated.
By their numbers in this assay, from the lowest: compounds 2, 1 and 3 (each within the scatter of the next).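

Methoxy to hydroxy now has one measured reading at this oxygen on an aromatic ring, taken with cyclohexyl on the amide-type nitrogen in the ring. In this assay, the change reads as (a 1.8-fold higher number from compound 1 to compound 3 (0.24 log units; within the scatter)), so compound 1 and compound 3 cannot be told apart, and on this one pair the methyl on the oxygen can be replaced by hydrogen without a step beyond the scatter. No measurement on hand explains this reading or shows what the oxygen substituent does in this series.

The compounds shown leave open whether methoxy to hydroxy gives a similar reading with phenyl on the amide-type nitrogen in the ring, since the single pair here carries cyclohexyl there. They also leave open how a longer chain on this oxygen, such as ethoxy or propoxy, would read in this assay, or a chain ending in an amine or a carboxylic acid, which would show whether this oxygen tolerates larger groups as well as it tolerates hydrogen.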